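The source may report more compounds than this note shows. Statements on the series, on what has been measured and on what is new or still open speak of the compounds shown alone.

Three amides that share one core have been tested in a functional assay on MDA-MB-231 cells (Homo sapiens) for antiproliferative activity, read by CCK-8 assay, with a stated time of 72 h; on this read-out higher numbers stand for weaker inhibition and lower numbers for stronger inhibition. Compound 1 `COc1ccc(C(=O)Nc2cccc(-c3oc4cc(-c5ccc(F)cc5)ccc4c(=O)c3O)c2)cc1` gives 16500 nM in this assay. Compound 2 `Cc1ccc(C(=O)Nc2cccc(-c3oc4cc(-c5ccc(F)cc5)ccc4c(=O)c3O)c2)cc1` gives 4350 nM, and the step of a 3.8-fold lower number from compound 1 to compound 2 (0.58 log units; beyond the scatter) shows that the methyl group brings a better number than the methoxy group. Compound 3 `O=C(Nc1cccc(-c2oc3cc(-c4ccc(F)cc4)ccc3c(=O)c2O)c1)c1ccc(Br)cc1` gives 24900 nM, the highest of the three numbers; the step of a 1.5-fold higher number from compound 1 to compound 3 (0.18 log units; within the scatter) is within the scatter, while the step of a 5.7-fold higher number from compound 2 to compound 3 (0.76 log units; beyond the scatter) is beyond it, so compound 3 is plainly weaker than compound 2 but not separable from compound 1.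

Compound 4 `Cc1cc(C(=O)Nc2cccc(-c3oc4cc(-c5ccc(F)cc5)ccc4c(=O)c3O)c2)ccc1F` has not yet been measured in this assay. It differs from compound 3 in one place: 4-fluoro-3-methylphenyl in place of 4-bromophenyl on a carbonyl carbon. Among the compounds with values here, no measured pair shows a fluorine on that ring, so the only step that bears on this change is the one between compound 2 and compound 3, where the methyl group gave the lower number. Since the entering group carries a methyl, compound 4 is expected to sit nearer compound 2 than compound 3, and the expected step is a 4.2-fold lower number from compound 3 to compound 4 (0.62 log units; beyond the scatter). Compound 4 is thus estimated to give 6000 nM, with a range from 2000 nM to 18000 nM.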

Compound 4, half-maximal inhibitory concentration: 7440 nM
Beside the measured number, compound 4's estimate is 1.2-fold (0.09 log units) below it; measured number inside the range.
By their numbers in this assay, from the lowest: compounds 2 and 4 (each within the scatter of the next); then compounds 1 and 3 (each within the scatter of the next).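

In this assay, the step of a 1.7-fold higher number from compound 2 to compound 4 (0.23 log units; within the scatter) cannot be separated from the scatter, so this position accepts 4-fluoro-3-methylphenyl in place of 4-methylphenyl without a readable change. The steps of a 3.3-fold lower number from compound 3 to compound 4 (0.52 log units; beyond the scatter) and a 2.2-fold lower number from compound 1 to compound 4 (0.35 log units; beyond the scatter) both lie beyond the scatter, which places the two methyl-bearing rings on the lower side of the 4-bromophenyl and 4-methoxyphenyl rings; among these four amides no compound goes against that split. No measurement at hand accounts for this split, and the result is a description of the numbers only.

The compounds shown leave open which part of the 4-fluoro-3-methylphenyl group matters, as a comparison would need a ring carrying the fluorine alone and one carrying the methyl alone in the same place. They also leave open how this position would respond to a group of another kind on that ring, such as an amine, a carboxylic acid or an ethyl chain in place of the methyl.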